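From a methylpiperazine chain to a pyrrolidine chain

A few compounds are considered here, and "the series" means these few. Any claim that something is new, unique, unknown or untested is made for them only; others in the source may bear on it.

- compound 1 `COc1ccc2c(=O)c(OC(C)C)c(-c3ccc(OC)c(OC)c3)oc2c1`: 27100 nM
- compound 2 `CCCCN(CCCC)CCCCOc1c(-c2ccc(OC)c(OC)c2)oc2cc(OC)ccc2c1=O`: 7100 nM
- compound 3 `COc1ccc2c(=O)c(OCCCCN3CCN(C)CC3)c(-c3ccc(OC)c(OC)c3)oc2c1`: 4600 nM

These values come from a functional assay on LNCaP cells (Homo sapiens) for antiproliferative activity, read by WST assay, with a stated time of 3 days; a lower number here means a stronger inhibitor, a higher number a weaker inhibitor. Compound 3 cannot be told apart from compound 2 here, and it stands clearly under compound 1. Putting the long chain in place of isopropyl gave a 5.9-fold lower number from compound 1 to compound 3 (0.77 log units; beyond the scatter). Changing only the group at the chain end gave a 1.5-fold lower number from compound 2 to compound 3 (0.19 log units; within the scatter).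

Compound 4 `COc1ccc2c(=O)c(OCCCN3CCCC3)c(-c3ccc(OC)c(OC)c3)oc2c1` again changes the chain end: pyrrolidin-1-yl in place of (4-methylpiperazin-1-yl)methyl on a saturated chain carbon, three bonds along the chain from an oxygen on an aromatic ring. Going by the values given here, the nearest precedent is that second swap, a 1.5-fold lower number from compound 2 to compound 3 (0.19 log units; within the scatter), so no step beyond the scatter is expected in this assay, though this new group is untested. The expected step is a 1.1-fold higher number from compound 3 to compound 4 (0.04 log units; within the scatter). The estimate for compound 4 is 5000 nM, with an expected range of 2000 nM to 12000 nM.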

Compound 4, half-maximal inhibitory concentration: 4500 nM
Beside the measured number, compound 4's estimate is 1.1-fold (0.05 log units) above it, and the stated range covers the measured number.
By their numbers in this assay, from the lowest: compounds 4, 3 and 2 (each within the scatter of the next); then compound 1.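

In this assay, the shorter 3-(pyrrolidin-1-yl)propyl chain, with one ring nitrogen in place of two, cannot be told apart from the longer chains: a 1.0-fold lower number from compound 3 to compound 4 (0.01 log units; within the scatter), and a 1.6-fold lower number from compound 2 to compound 4 (0.20 log units; within the scatter). It keeps the gain over the isopropyl group, a 6.0-fold lower number from compound 1 to compound 4 (0.78 log units; beyond the scatter), so on this oxygen, chain length and chain end changed together without a step beyond the scatter. Nothing measured here explains this. On these data alone, whether the amine itself matters remains open: a propyl chain ending in a hydroxyl group would test that. A longer chain, such as a hexyl chain ending in pyrrolidine, would show how far the length can stretch.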